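The compounds below may be only part of what the source reports. "The series", "measured", "known", "first", "only" and "open" are said of these compounds alone.

Three compounds share one core and differ only in the aromatic ring attached to the carbonyl carbon of the acyl hydrazine arm. Compound 1 `CCNC(=O)[C@H]1O[C@@H](n2cnc3c(NNC(=O)c4ccco4)nc(Cl)nc32)[C@H](O)[C@@H]1O` carries furan-2-yl there, and in an assay on CHO cells for displacement of a labelled ligand from adenosine receptor A1 (Homo sapiens) (a higher number here means a weaker inhibitor, a lower number a stronger inhibitor), compound 1 gives 3500 nM. Compound 2 `CCNC(=O)[C@H]1O[C@@H](n2cnc3c(NNC(=O)c4sccc4C)nc(Cl)nc32)[C@H](O)[C@@H]1O` carries 3-methylthiophen-2-yl, and in this assay compound 2 gives 1600 nM. Compound 3 `CCNC(=O)[C@H]1O[C@@H](n2cnc3c(NNC(=O)c4ccc[nH]4)nc(Cl)nc32)[C@H](O)[C@@H]1O` carries 1H-pyrrol-2-yl, and in this assay compound 3 gives 610 nM. Compound 3 therefore stands at the lowest number of the three: the step of a 2.6-fold lower number from compound 2 to compound 3 (0.42 log units; beyond the scatter) and the step of a 5.7-fold lower number from compound 1 to compound 3 (0.76 log units; beyond the scatter) both lie beyond the scatter, as does the step of a 2.2-fold lower number from compound 1 to compound 2 (0.34 log units; beyond the scatter).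

Compound 4 `CCNC(=O)[C@H]1O[C@@H](n2cnc3c(NNC(=O)c4cc(C)on4)nc(Cl)nc32)[C@H](O)[C@@H]1O` is the next member of the series. The change from compound 3 is 5-methyl-1,2-oxazol-3-yl in place of 1H-pyrrol-2-yl on a carbonyl carbon. All three measured steps bear on this change, since each of them also exchanges the ring on that carbonyl carbon, and they show that the ring with the hydrogen-bond donor gave the lowest number while the two rings without one gave higher numbers. The ring entering in compound 4 has no hydrogen-bond donor either, so a step back toward the numbers of compounds 1 and 2 is expected, with the size a 4.1-fold higher number from compound 3 to compound 4 (0.61 log units; beyond the scatter) in this assay. On that basis compound 4 is estimated at 2500 nM, within a range from 800 nM to 8000 nM.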

Compound 4, inhibition constant: > 5000 nM
Compound 4: no number, only a limit; the forecaster's own chance of this, stated with the estimate: 5%; at least 2.0-fold (0.30 log units) between middle value and limit.
By their numbers in this assay, from the lowest: compound 3; then compound 2; then compound 1. At a limit, above all of these: compound 4.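

Compound 4 gives no number in this assay, only a limit: the limit of > 5000 nM in this assay, at which 1 of the 4 values shown sits. Even as a floor, an at least 8.1-fold higher number from compound 3 to compound 4 (0.91 log units; beyond the scatter) is wider than any step among the earlier compounds, and an at least 3.1-fold higher number from compound 2 to compound 4 (0.49 log units; beyond the scatter) shows that the exchange of this ring on the carbonyl carbon can also carry the number clearly past that of a ring without a hydrogen-bond donor. Against the furan-2-yl ring the reading is less firm: an at least 1.4-fold higher number from compound 1 to compound 4 (0.15 log units; that floor lies within the scatter) has a floor within the scatter, so the limit does not order these two compounds, and 1H-pyrrol-2-yl, the one ring here with a hydrogen-bond donor, simply remains at the lowest number.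

From the compounds shown here alone, how far above the limit compound 4 lies stays unknown, and so does the true size of all three new steps. The compounds shown also leave open whether the hydrogen on the ring nitrogen of 1H-pyrrol-2-yl goes with the low number of compound 3, which a 1-methyl-1H-pyrrol-2-yl ring on the same carbonyl carbon would address, and whether the methyl group of 5-methyl-1,2-oxazol-3-yl plays any part, which the unmethylated 1,2-oxazol-3-yl ring would address.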